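From a Nitrile to a Trifluoromethoxy Group on the Anilide

A few compounds are considered here, and "the series" means these few. Any claim that something is new, unique, unknown or untested is made for them only; others in the source may bear on it.

Three salicylanilides have been measured in a functional assay on HL-60 cells (Homo sapiens) for cytotoxicity, read by luminescence and CellTiter-Glo, with a stated time of 3 days; a higher number here means a weaker inhibitor, a lower number a stronger inhibitor. Compound 1 `O=C(Nc1ccc(Cl)c(Br)c1)c1cc(Cl)ccc1O` gives 780 nM in this assay, compound 2 `N#Cc1ccc(NC(=O)c2cc(Cc3ccccc3)ccc2O)cc1` gives 1740 nM, and compound 3 `N#Cc1ccc(NC(=O)c2cc(Cl)ccc2O)c(Cl)c1` gives 500 nM. Compound 3 has the lowest number of the three; the gap to compound 1 lies within the scatter, while compound 2 stands beyond it. Compound 4 `O=C(Nc1ccc(OC(F)(F)F)cc1Cl)c1cc(Cl)ccc1O` has not yet been measured. It differs from compound 3 in one place: trifluoromethoxy in place of cyano on an aromatic carbon. Going by the values given here, no measured pair shows this change, so its effect is not known from the data. A small step is expected, a 1.3-fold higher number from compound 3 to compound 4 (0.11 log units; within the scatter), in either direction or none beyond the scatter. For compound 4 an estimate of 650 nM is given, with a range from 250 nM to 1700 nM.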

Compound 4, half-maximal inhibitory concentration: 650 nM
Compound 4: middle estimate and measured number agree at the digits printed, and the stated range covers the measured number.
By their numbers in this assay, from the lowest: compounds 3, 4 and 1 (each within the scatter of the next); then compound 2.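

The step from cyano to trifluoromethoxy on this aromatic carbon, para to a large group and meta to a chloro group, is a 1.3-fold higher number from compound 3 to compound 4 (0.11 log units; within the scatter) in this assay. Going by these compounds alone, the position thus accepts a group of five heavy atoms in place of one of two with no change beyond the scatter, which no earlier pair could show. Nothing available explains why the step is this small.

From the compounds shown here alone, whether an amine, a carboxylic acid or a longer chain on this carbon would also stay within the scatter remains open. So does whether this exchange behaves alike on another core, as only this one pair shows it.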